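The source may hold more compounds than are shown below. What is called first, only, known or untested is meant among the compounds shown, and "the series" means these compounds.

Measured so far in an ADME assay on SW480 cells (Homo sapiens) for cytotoxicity, read by MTT assay, with a stated time of 72 h; on this read-out higher numbers stand for weaker inhibition and lower numbers for stronger inhibition:

Compound 1, `Cc1ccc(NC(=O)c2cccc(/C=C3\CC(=O)N(c4ccccc4)C3=O)c2)cc1` — > 100000 nM
Compound 2, `Cc1ccc(N2C(=O)C/C(=C\c3cccc(C(=O)Nc4ccc(Cl)cc4)c3)C2=O)cc1` — > 100000 nM
Compound 3, `CCCCCN1C(=O)C/C(=C\c2cccc(C(=O)Nc3cccc(F)c3)c2)C1=O` — > 100000 nM

In this assay compound 1 stands at a limit of the assay, not at a measured number. The same is true of compound 2 in this assay, and of compound 3 in this assay, so that every reading shown sits at the limit of > 100000 nM in this assay, at which 3 of the 3 values shown sit. Within the data shown here, no pair of these measured compounds differs in a single place, so no measured step can be read from them; all that can be said of compounds 1, 2 and 3 is that none of them reached a numerical value.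

Compound 4, `CCOc1ccc(NC(=O)c2cccc(/C=C3\CC(=O)N(c4ccccc4)C3=O)c2)cc1`, is the compound still to be measured. It differs from compound 1 in one place: ethoxy in place of methyl on an aromatic carbon. Compound 1 gives only a limit in this assay, and the two other compounds do the same, so there is no measured change of any size to lean on.

The step that the limit leaves unreadable from compound 1 to compound 4 in this assay is therefore expected to be none beyond the usual scatter. Compound 4 is expected to give about 150000 nM in this assay, with a range from 50000 nM to 500000 nM, and most likely it will again be reported only as a limit.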

Compound 4, half-maximal inhibitory concentration: 91500 nM
Compound 4: the middle estimate sits 1.6-fold (0.21 log units) above what was measured; the measured number falls inside the stated range.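

In this assay compound 4 gives 91500 nM, the only reading among the compounds shown that is an actual number, so ethoxy in place of methyl at this position, on an aromatic carbon para to a large group, yields a measurable value on the shared core. Compound 1 gives > 100000 nM, which is a limit of the assay and not a number. The change can therefore be read only as an at least 1.0-fold lower number from compound 1 to compound 4 (0.03 log units; that floor lies within the scatter), and its true size stays unknown because compound 1 has no number of its own: the limit of > 100000 nM in this assay, at which 3 of the 4 values shown sit.

The compounds shown do not separate the effect of the oxygen in ethoxy from that of its greater length, which a methoxy or a propyl group at the same position on the core of compound 1 could do. They also leave open whether an amine or a carboxylic acid there would give a value clearly different from that of compound 4, or whether ethoxy would give a number on other cores.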